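The compounds below may be only part of what the source reports. "The series", "measured", "known", "first", "only" and "open" are said of these compounds alone.

Measured so far:
- Compound 1 `O=S(=O)(c1ccc(F)c(Cl)c1)c1cnc2c(F)cccc2c1-c1ccc(F)cc1`: 0.19 mL/min
- Compound 2 `COc1ccc(S(=O)(=O)c2cnc3c(F)cccc3c2-c2cccc(F)c2)cc1`: 3.03 mL/min
- Compound 3 `O=S(=O)(c1ccc(F)c(Cl)c1)c1cnc2c(F)cccc2c1-c1ccccc1F`: 1.39 mL/min

In an ADME assay on microsomes from liver (Homo sapiens) for metabolic stability, tested at 2.5 uM (on this read-out higher numbers stand for fast clearance and lower numbers for slow clearance), compound 3 sits second highest of the three numbers. Its nearest neighbour is compound 2, which gives 3.03 mL/min, a gap beyond the scatter. Its furthest is compound 1, which gives 0.19 mL/min.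

Compound 4 `O=S(=O)(c1ccc(F)c(Cl)c1)c1cnc2c(F)cccc2c1-c1cccc(F)c1` is not yet measured. It differs from compound 3 in one place: 3-fluorophenyl in place of 2-fluorophenyl on an aromatic carbon.

For the measured compounds named here, the one measured step that bears on this position is the move from compound 1 to compound 3, a 7.3-fold higher number from compound 1 to compound 3 (0.86 log units; beyond the scatter). That step moved the fluorine from one site on the pendant phenyl to another and carried a clear rise in this assay. Going by the values given here, the move from compound 3 to compound 4 shifts the same fluorine once more, to a third site for which no direct step is recorded. Among the compounds with values here, compound 2, which also carries a 3-fluorophenyl but a different sulfonyl aryl, gives 3.03 mL/min; no step links it to compound 4, so it serves only as a loose pointer that a 3-fluorophenyl can go with a high number.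

On balance compound 4 is expected to land between compound 1 and compound 3, so the step of a 1.4-fold lower number from compound 3 to compound 4 (0.14 log units; within the scatter) is expected to stay within or near the scatter. The estimate for compound 4 is 1 mL/min, with a range from 0.3 mL/min to 3 mL/min.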

Compound 4, intrinsic clearance in a liver preparation (reported as CLH), per the amount of preparation that the assay uses: 1.23 mL/min
Compound 4: the middle estimate sits 1.2-fold (0.09 log units) below what was measured; measured number inside the range.
By their numbers in this assay, from the lowest: compound 1; then compounds 4 and 3 (each within the scatter of the next); then compound 2.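

In this assay the 3-fluorophenyl and 2-fluorophenyl groups on this aromatic carbon cannot be told apart, with a 1.1-fold lower number from compound 3 to compound 4 (0.05 log units; within the scatter) as the step between them. The 4-fluorophenyl now stands alone among the three fluorophenyl groups at this place, since a 6.5-fold higher number from compound 1 to compound 4 (0.81 log units; beyond the scatter) is a step of similar size to a 7.3-fold higher number from compound 1 to compound 3 (0.86 log units; beyond the scatter) and both lie beyond the scatter. With the 3-fluorophenyl held fixed, the sulfonyl side also gets its first direct reading, a 2.5-fold lower number from compound 2 to compound 4 (0.39 log units; beyond the scatter) for 3-chloro-4-fluorophenyl in place of 4-methoxyphenyl on the sulfonyl sulfur.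

Still open, from the compounds shown here alone, is whether the low number of compound 1 is tied to the 4-fluorophenyl itself or also comes with a 4-chlorophenyl, a 4-cyanophenyl or an unsubstituted phenyl on this carbon, and whether the 2-fluorophenyl and 3-fluorophenyl stay level with a different aryl on the sulfonyl sulfur. No measurement at hand offers an explanation for why the 4-fluorophenyl stands apart from the other two groups.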